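From Methoxy to Pentyloxy on a Shared Core

A few compounds are considered here, and "the series" means these few. Any claim that something is new, unique, unknown or untested is made for them only; others in the source may bear on it.

Of the compounds shown here, three built on one shared core have been tested in a functional assay on SMMC-7721 cells (Homo sapiens) for cytotoxicity, read by MTT assay, with a stated time of 72 h; a higher number here means a weaker inhibitor, a lower number a stronger inhibitor. Compound 1 `[O-][n+]1nc(NCOC2CCCCC2)[n+]([O-])c2ccccc21` gives 28200 nM. Compound 2 `COCNc1n[n+]([O-])c2ccccc2[n+]1[O-]` gives 6670 nM, and compound 3 `COc1ccc2c(c1)[n+]([O-])nc(NCOCc1ccccc1)[n+]2[O-]`, which carries an additional methoxy on the core, gives 21400 nM. Compound 2 stands lowest of the three: compound 3 is nearest to it and compound 1 furthest, both beyond the scatter. Among the compounds with values here, the only step between compounds that differ in a single place is a 4.2-fold lower number from compound 1 to compound 2 (0.63 log units; beyond the scatter). Compound 3 differs from compound 2 in two places, so its value can only be set beside that of compound 2.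

The next compound, compound 4 `CCCCCOCNc1n[n+]([O-])c2ccccc2[n+]1[O-]`, is the pentyloxy counterpart of compound 2. Its difference from compound 2 is butyl in place of hydrogen on a saturated chain carbon bound to an oxygen on a saturated carbon.

The step from compound 1 to compound 2 is the one that bears on this change: methyl in place of cyclohexyl lowered the number, and compound 3, with benzyl in that position, also shows a higher value than compound 2. The author therefore expects the butyl addition to raise the number in this assay modestly, with a 2.2-fold higher number from compound 2 to compound 4 (0.35 log units; beyond the scatter). Compound 4 is estimated at 15000 nM, within a range from 6000 nM to 40000 nM.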

Compound 4, half-maximal inhibitory concentration: 17000 nM
The estimate for compound 4 lay 1.1-fold (0.05 log units) below the measured number; low and high end bracket the measured number.
By their numbers in this assay, from the lowest: compound 2; then compounds 4, 3 and 1 (each within the scatter of the next).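

In this assay, the step to a longer open chain on the oxygen gives a 2.5-fold higher number from compound 2 to compound 4 (0.41 log units; beyond the scatter) and so shows that the number at this position moves without any ring entering, whereas the earlier step at this position had exchanged cyclohexyl for methyl. The other new step, a 1.7-fold lower number from compound 1 to compound 4 (0.22 log units; within the scatter) in size, does not separate pentyl from cyclohexyl on this oxygen, so a ring and an open chain cannot be told apart in this pair. Among the three compounds that differ only at this position, methyl in compound 2 therefore stands alone at the low end, with both pentyl and cyclohexyl giving higher numbers than methyl beyond the scatter.

The compounds shown leave open whether the number climbs step by step along the chain or already reaches this level with an ethyl or a propyl group, and whether a pentyl chain ending in an amine or a carboxylic acid would behave as the plain pentyl chain does. Nothing at hand explains why the number shifts with this change.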